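Compound 3 to compound 4: methoxy in place of methyl

The source may hold more compounds than are shown below. What is called first, only, known or untested is meant among the compounds shown, and "the series" means these compounds.

Measured in an ADME assay on MDCK cells (Canis lupus familiaris) for cytotoxicity, read by MTT assay, with a stated time of 24 h; on this read-out higher numbers stand for lower toxicity in this test and lower numbers for higher toxicity in this test:
- compound 1 `COc1ccc(S(=O)(=O)N(CCC#N)Cc2cccs2)cc1`: > 198000 nM
- compound 2 `N#CCCN(Cc1ccco1)S(=O)(=O)c1ccc(Br)cc1`: > 180000 nM
- compound 3 `Cc1ccc(S(=O)(=O)N(CCC#N)Cc2ccco2)cc1`: > 219000 nM

All three readings are limits of the assay and not numbers. Compound 3 therefore stands at a limit, > 219000 nM, with the other two compounds also at limits.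

Compound 4 `COc1ccc(S(=O)(=O)N(CCC#N)Cc2ccco2)cc1` is the next entry, and it differs from compound 3 at one place: methoxy in place of methyl on an aromatic carbon. The change is methoxy in place of methyl on an aromatic carbon, para to a large group.

For the measured compounds named here, the one measured step with a change of this kind is a step that the two limits leave unreadable from compound 2 to compound 3, so it gives no size to carry over. Going by the values given here, compound 1 is the only measured compound that carries methoxy, and it also gives only a limit, > 198000 nM. Among the compounds with values here, no measured compound in this assay has yet given a number, so there is no basis for a direction.

The expected step is an at least 1.0-fold lower number from compound 3 to compound 4 (0.02 log units; that floor lies within the scatter), which means none beyond the scatter, and a limit is the likely report. For compound 4 the estimated value is 208000 nM, with an expected range of 130000 nM to 320000 nM.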

Compound 4, half-maximal cytotoxic concentration: > 208000 nM
Compound 4 gave a limit, no number; the forecaster's own chance of this, stated with the estimate: 90%; the middle value sits exactly at the limit.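

In this assay compound 4 gives > 208000 nM, a limit of the assay and not a number. The steps to compound 4 from compound 1, compound 2 and compound 3 cannot be read, as all four readings are limits. The compounds shown leave open whether any of these group changes shifts the read-out at all.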